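Volume of distribution from a difluorocyclobutyl to an oxanyl amide

The compounds below may be only part of what the source reports. "The series", "measured", "known", "first", "only" and "open" are said of these compounds alone.

Measured compounds:
- compound 1 `CCn1c(-c2cnc(C)nc2)nc2c(N[C@H]3CCN(C(=O)C4CC(F)(F)C4)C3)ncnc21`: 18 L/kg
- compound 2 `CCn1c(-c2cnc(C)nc2)nc2c(O[C@H]3CCN(C(=O)C4CC(F)(F)C4)C3)ncnc21`: 3 L/kg
- compound 3 `CCn1c(-c2ccc(C(F)(F)F)nc2)nc2c(O[C@H]3CCN(C(=O)C4CC4)C3)ncnc21`: 8.3 L/kg

Of the compounds shown here, three sharing the same core have been tested in an ADME assay (Rattus norvegicus, strain Wistar Han) for pharmacokinetics; a lower number here means that more of the compound stays in the plasma, a higher number that more of the compound sits outside the plasma. In this assay compound 1 gives 18 L/kg, the highest of the three numbers. Its nearest neighbour is compound 3, with 8.3 L/kg, and the gap between them lies beyond the usual scatter. Compound 2, with 3 L/kg, stands furthest from compound 1, again beyond the scatter. Going by the values given here, compounds 2 and 3 differ from compound 1 in more than one place, so no single step between measured compounds is available to guide the next one.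

Compound 4 `CCn1c(-c2cnc(C)nc2)nc2c(N[C@H]3CCN(C(=O)C4CCOCC4)C3)ncnc21` has not yet been measured in this assay. It differs from compound 1 in a single place: oxan-4-yl in place of 3,3-difluorocyclobutyl on a carbonyl carbon. Among the compounds with values here, with no measured step of this kind to lean on, the step from compound 1 to compound 4 is expected to be a modest one downward, possibly no larger than the scatter, a 1.8-fold lower number from compound 1 to compound 4 (0.26 log units; within the scatter). On that basis compound 4 is estimated to give 10 L/kg in this assay, with a range from 4 L/kg to 25 L/kg.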

Compound 4, volume of distribution: 4.3 L/kg
Beside the measured number, compound 4's estimate is 2.3-fold (0.37 log units) above it, and the stated range covers the measured number.
By their numbers in this assay, from the lowest: compounds 2, 4 and 3 (each within the scatter of the next, the first and the last beyond it); then compound 1.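

In this assay, going by these compounds alone, the change from 3,3-difluorocyclobutyl to oxan-4-yl on a carbonyl carbon gives the first single-place step in this set, a 4.2-fold lower number from compound 1 to compound 4 (0.62 log units; beyond the scatter), which shows that the group at this position can alone move the number beyond the scatter. Both groups hold 6 heavy atoms and carry no net charge, so a step of this size arises with the heavy-atom count unchanged, while the ring goes from four-membered to six-membered and gains a hydrogen-bond acceptor. Nothing measured here accounts for the step.

The compounds shown leave open which part of the change carries the step, a question that plain cyclobutyl or cyclohexyl on the same carbonyl carbon could help to separate. They also leave open whether the same change on compound 2 gives a step of similar size.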